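The source may report more compounds than this note shows. Statements on the series, on what has been measured and on what is new or still open speak of the compounds shown alone.

Measured in an ADME assay on cells (Hepatocyte, Rattus norvegicus, strain Wistar) for pharmacokinetics, read by LC-MS, with a stated time of 90 min, tested at 1 uM; on this read-out lower numbers stand for slow clearance and higher numbers for fast clearance:
- compound 1 `COc1cc(C(=O)N2CCC(O)C(C)C2)cc2nc(NCc3cccc(Cl)c3)oc12`: 45 mL/min/kg
- compound 2 `COc1cc(C(=O)N2CC[C@@H](O)[C@H](C)C2)cc2nc(NCc3cccc(Cl)c3)oc12`: 38.3 mL/min/kg
- compound 3 `COc1cc(C(=O)N2CC[C@H](O)[C@@H](C)C2)cc2nc(NCc3cccc(Cl)c3)oc12`: 36.7 mL/min/kg

Compound 1 lies within the scatter of both compound 2 and compound 3. Compound 4 `COc1cc(C(=O)N2CCC(O)C(C)C2)cc2nc(NCc3cc(Cl)ccn3)oc12` carries 4-chloropyridin-2-yl in place of 3-chlorophenyl on a saturated chain carbon bound to a nitrogen on an aromatic ring.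

The measured steps of a 1.2-fold lower number from compound 1 to compound 2 (0.07 log units; within the scatter), a 1.2-fold lower number from compound 1 to compound 3 (0.09 log units; within the scatter) and a 1.0-fold lower number from compound 2 to compound 3 (0.02 log units; within the scatter) concern configuration only, so they give no direct size for this change. In this assay, no step beyond the scatter is expected, perhaps with a somewhat lower number. For compound 4 the estimated value is 33 mL/min/kg, with an expected range of 17 mL/min/kg to 55 mL/min/kg. The estimated step is a 1.4-fold lower number from compound 1 to compound 4 (0.13 log units; within the scatter).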

Compound 4, clearance: 14.3 mL/min/kg
For compound 4 the middle estimate is 2.3-fold (0.36 log units) above the measured one, outside the stated range (below it).
By their numbers in this assay, from the lowest: compound 4; then compounds 3, 2 and 1 (each within the scatter of the next).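

In this assay, among the compounds shown here, 4-chloropyridin-2-yl in place of 3-chlorophenyl gives a 3.1-fold lower number from compound 1 to compound 4 (0.50 log units; beyond the scatter), the only step in this set beyond the scatter; the steps among compounds 1, 2 and 3 all stay within it. This place, on a saturated chain carbon bound to a nitrogen on an aromatic ring, therefore moves this read-out where the configuration as drawn did not. Nothing at hand accounts for the step. Open, on these data alone, is whether pyridin-2-yl without chlorine or a pyrimidin-2-yl ring gives a similar number. Also open, as far as these compounds go, is how the defined configurations behave with 4-chloropyridin-2-yl in place.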